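Fluoro for methoxy in an amidine series

A few compounds are considered here, and "the series" means these few. Any claim that something is new, unique, unknown or untested is made for them only; others in the source may bear on it.

Measured compounds in a functional assay on HOP-92 cells (Homo sapiens) for inhibition, read by sulforhodamine B assay, with a stated time of 48 h; on this read-out lower numbers stand for stronger inhibition of growth and higher numbers for weaker inhibition of growth:
compound 1 `COc1ccc(-c2ccc(-c3ccc(C(=N)N)o3)o2)cc1` — "not determined" (no result reported)
compound 2 `N=C(N)c1ccc(-c2ccc(-c3ccc(Cl)cc3)s2)s1` — 1810 nM
compound 3 `COc1cc(OC)cc(-c2ccc(-c3ccc(C(=N)N)o3)o2)c1` — "not determined" (no result reported)

Compound 1 has no place on the numbers: in this assay compound 1 gives "not determined" (no result reported), and compound 3 likewise gives "not determined" (no result reported). Going by the values given here, the only number in the set comes from compound 2, which in this assay gives 1810 nM. Among the compounds with values here, compound 2 differs from compound 1 in more than one place, so no single step is recorded between them, and its value serves only as a rough level for the series.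

Compound 4 `N=C(N)c1ccc(-c2ccc(-c3ccc(F)cc3)o2)o1` arises from compound 1 by fluoro in place of methoxy on an aromatic carbon. Within the data shown here, no step between measured compounds is recorded, so the size of this change cannot be read from the data. Because compound 1 gives "not determined" (no result reported), no direction can be set for the step either; the working expectation is a change that stays within the scatter of this assay, with the series level set by compound 2. Compound 4 is expected to give about 2500 nM in this assay, within a range from 600 nM to 10000 nM. Among the measured compounds shown here, this rests on compound 2, whose value of 1810 nM is the only number in the set.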

Compound 4, concentration for 50% growth inhibition: 1210 nM
Estimate against measurement, compound 4: 2.1-fold (0.32 log units) above; low and high end bracket the measured number.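

No step can be read from compound 1 to compound 4: in this assay compound 1 gives "not determined" (no result reported) while compound 4 gives 1210 nM as its result. No evidence bears on this result.

The compounds shown leave open what fluoro in place of methoxy does to growth inhibition on the shared core.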